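The source may hold more compounds than are shown below. What is called first, only, known or untested is meant among the compounds shown, and "the series" means these compounds.

Measured compounds:
compound 1, `COc1ccc(C(O)(Cc2ccc(F)cc2)c2cccc3ccccc23)c(OC)c1OC` — 5940 nM
compound 2, `COc1ccc(/C(=N/OC(C)=O)c2cccc3ccccc23)c(OC)c1OC` — 17200 nM
compound 3, `COc1ccc(C(c2ccc(OCCO)cc2)c2cccc3ccccc23)c(OC)c1OC` — > 20000 nM

Of the compounds shown here, three share a trimethoxyphenyl-naphthyl core and have been tested in a functional assay on A549 cells (Homo sapiens) for inhibition, read by sulforhodamine B assay, with a stated time of 48 h; a lower number here means a stronger inhibitor, a higher number a weaker inhibitor. Compound 1 gives 5940 nM in this assay. Compound 2 gives 17200 nM, the higher of the two numbers, so compound 2 is the weaker inhibitor of the pair, and the gap to compound 1 lies beyond the usual scatter. For compound 3 this assay reports only a limit, > 20000 nM, and not a number; this is the case noted as the limit of > 20000 nM in this assay, at which 1 of the 3 values shown sits.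

Compound 4, `CCOC(=O)/C=C/CO/N=C(/c1ccc(OC)c(OC)c1OC)c1cccc2ccccc12`, has not yet been measured. It differs from compound 2 in one place, (3-(ethoxycarbonyl)prop-2-en-1-yl in place of acetyl on an oxygen), a change in the group that hangs on the oxygen of the oxime. Going by the values given here, no pair among the measured compounds mirrors this exchange, so there is no measured step to lean on. The expectation is therefore that compound 4 sits close to compound 2, with a step from compound 2 to compound 4 of a 1.1-fold lower number from compound 2 to compound 4 (0.06 log units; within the scatter), not clearly beyond the scatter in either direction. Compound 4 is estimated at 15000 nM, within a range of 5000 nM to 40000 nM.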

Compound 4, half-maximal inhibitory concentration: 14000 nM
The estimate for compound 4 lay 1.1-fold (0.03 log units) above the measured number, within the range that was stated.
By their numbers in this assay, from the lowest: compound 1; then compounds 4 and 2 (each within the scatter of the next). At a limit, above all of these: compound 3.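

Replacing acetyl with 3-(ethoxycarbonyl)prop-2-en-1-yl on this oxygen, whose other neighbour is a double-bonded nitrogen, gives a 1.2-fold lower number from compound 2 to compound 4 (0.09 log units; within the scatter) in this assay, so the two compounds cannot be told apart by this read-out. Going by these compounds alone, this is the first measured step at this position, and it shows that a group of 8 heavy atoms can stand in place of one of 3, with a second hydrogen-bond acceptor and an extra double bond, without a step beyond the scatter; this holds for these two groups only and makes no general rule for the position. Nothing measured here gives a reason for this result.

The compounds shown leave open whether a different kind of group on this oxygen, such as an amine or a carboxylic acid at the end of the chain, would give a step beyond the scatter in either direction. They also leave open how the bare oxime hydroxyl, or a small methyl group on the same oxygen, would compare with acetyl.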